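The source may report more compounds than this note shows. Statements on the series, on what has been measured and on what is new or still open speak of the compounds shown alone.

Compound 3 `CCCc1cc(N)c2cc(NC(=O)/C=C/c3ccc(CC)cc3)ccc2n1` gives 1.4 nM in an assay on isolated protein for displacement of a labelled ligand from melanin-concentrating hormone receptor 1 (Homo sapiens) (a lower number here means a stronger inhibitor, a higher number a weaker inhibitor), the lowest of the three numbers recorded. Its nearest neighbour is compound 1 `CCCc1cc(N)c2cc(NC(=O)/C=C/c3ccc(Cl)cc3)ccc2n1`, which gives 6 nM; the furthest is compound 2 `CCCc1cc(N)c2cc(NC(=O)/C=C/c3ccc(N)cc3)ccc2n1`, which gives 190 nM. The two steps leading to compound 3 both lowered the number: a 4.3-fold lower number from compound 1 to compound 3 (0.63 log units; beyond the scatter) and a 140-fold lower number from compound 2 to compound 3 (2.13 log units; beyond the scatter).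

Compound 4 `CCCc1cc(N)c2cc(NC(=O)/C=C/c3ccc(C(C)(C)C)cc3)ccc2n1` differs from compound 3 in one place: tert-butyl in place of ethyl on an aromatic carbon. Within the data shown here, no measured pair compares tert-butyl with ethyl at this position, so the only direct guide is the chloro-to-ethyl step, a 4.3-fold lower number from compound 1 to compound 3 (0.63 log units; beyond the scatter), which was modest, and the amino-to-ethyl step, a 140-fold lower number from compound 2 to compound 3 (2.13 log units; beyond the scatter), which was large but involves a very different group. With one alkyl group replacing another and no donor or acceptor gained or lost, the change is expected to be small relative to those steps.

Compound 4 is therefore expected to sit close to compound 3, with a step of a 1.4-fold higher number from compound 3 to compound 4 (0.15 log units; within the scatter) that would lie within or barely beyond the scatter, in either direction. The estimate for compound 4 in this assay is 2 nM, with a plausible range from 0.5 nM to 8 nM.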

Compound 4, half-maximal inhibitory concentration: 22 nM
Estimate against measurement, compound 4: 11-fold (1.04 log units) below, and the stated range ends below it.
By their numbers in this assay, from the lowest: compound 3; then compound 1; then compound 4; then compound 2.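

In this assay, the group para to a large group proves sensitive even to an exchange of one alkyl group for another, with no hydrogen-bond donor or acceptor entering or leaving: the step is a 16-fold higher number from compound 3 to compound 4 (1.20 log units; beyond the scatter) and it counts as large. An alkyl group here therefore does not by itself give a low number, since tert-butyl falls behind chloro, with a 3.7-fold higher number from compound 1 to compound 4 (0.56 log units; beyond the scatter), although it still improves on amino, with an 8.6-fold lower number from compound 2 to compound 4 (0.94 log units; beyond the scatter) and that step is modest. Among these four compounds, the number does not follow the count of heavy atoms in any simple way, and no measurement shown bears on why tert-butyl raises it relative to ethyl.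

The compounds shown leave open how the number changes between ethyl and tert-butyl, which isopropyl or a longer chain such as propyl or butyl could help to trace. They also leave open whether methyl, methoxy or trifluoromethyl at the same place would give a number nearer that of compound 3 or that of compound 4.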